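Swapping thiophen-2-yl for 1-benzofuran-2-yl: a question of tolerance

This account rests on a few compounds, and the source may have more. Where it says the series, first, only, none or still open, it means among the compounds named here.

Compound 1 `CCCCCCCCCCCCCCCCCCOP(=O)(O)OC[C@H]1O[C@@H](n2ccc3c(-c4ccccc4)ncnc32)[C@H](O)[C@@H]1O`, compound 2 `CCCCCCCCCCCCCCCCCCOP(=O)(O)OC[C@H]1O[C@@H](n2ccc3c(-c4cccs4)ncnc32)[C@H](O)[C@@H]1O` and compound 3 `CCCCCCCCCCCCCCCCCCOP(=O)(O)OC[C@H]1O[C@@H](n2ccc3c(-c4cc5ccccc5o4)ncnc32)[C@H](O)[C@@H]1O` form a small series, and the question here is how much of each compound cells tolerate. This is measured in an ADME assay on BJ cells (Homo sapiens) for cytotoxicity, read by MTT assay, with a stated time of 72 h; a lower number here means that less compound is tolerated, a higher number that more compound is tolerated. In this test, compound 1 gives > 50000 nM, which is a limit of the assay and not a number. Compound 2 has no place on the scale at all, since its entry reads "not determined" (no result reported). Among the compounds with values here, the series therefore offers no measured step to learn from.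

The change to follow is 1-benzofuran-2-yl in place of thiophen-2-yl on an aromatic carbon. It puts 1-benzofuran-2-yl in place of thiophen-2-yl on an aromatic carbon, next to the ring nitrogen of a six-membered aromatic ring with 2 nitrogen. Within the data shown here, the only guide is compound 1 at > 50000 nM, so no step beyond the usual scatter is expected in this assay, and any small shift would most likely be towards less compound being tolerated. The assay may well report only a limit again. For compound 3, the estimated value is 35000 nM, with an expected range from 10000 nM to 50000 nM.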

Compound 3, half-maximal cytotoxic concentration: > 50000 nM
Compound 3: a limit, no number; the forecaster's own chance of this, stated with the estimate: 70%; middle value at least 1.4-fold (0.15 log units) away from the limit.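

In this assay compound 3 gives > 50000 nM, which is a limit of the assay and not a number. No step can be read among compound 1, compound 2 and compound 3, since the values that could be compared are limits: the limit of > 50000 nM in this assay, at which 2 of the 3 values shown sit.

From the compounds shown here alone, whether 1-benzofuran-2-yl in place of thiophen-2-yl changes how much compound cells tolerate stays open.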